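Replacing Fluoro with Dimethylamino in Compound 3

This account rests on a few compounds, and the source may have more. Where it says the series, first, only, none or still open, it means among the compounds named here.

Of the compounds shown here, three on a shared core have so far been measured in a physicochemical assay for lipophilicity (a higher number here means a more lipophilic compound, a lower number a more polar compound), for this comparison. Compound 1 `O=C1/C(=C/c2ccc(Cl)cc2)CCC/C1=C\c1ccccc1[N+](=O)[O-]` gives 5.38 and compound 2 `CN(C)c1ccc(/C=C2\CCC/C(=C\c3ccccc3[N+](=O)[O-])C2=O)cc1` gives 4.8 there. Compound 3 `O=C1/C(=C/c2ccc(F)cc2)CCC/C1=C\c1ccc([N+](=O)[O-])cc1` gives 5.09 on the same scale, a number within the scatter of both others, although those two lie apart beyond it.

Compound 4 `CN(C)c1ccc(/C=C2\CCC/C(=C\c3ccc([N+](=O)[O-])cc3)C2=O)cc1` is still unmeasured. It departs from compound 3 in one place, with dimethylamino in place of fluoro on an aromatic carbon, para to a large group (dimethylamino in place of fluoro on an aromatic carbon).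

Within the data shown here, one measured step bears on this change. That step is a number 0.58 log units lower from compound 1 to compound 2 (beyond the scatter) and it puts dimethylamino in place of chloro on an aromatic carbon, a modest move beyond the scatter. It is an indirect guide: the group leaving there is chloro, not fluoro, and compound 1 and compound 3 also differ in the placing of the nitro group. Among the measured compounds shown here, no step from fluoro to dimethylamino has been measured.

A modest step of similar size toward a lower number is therefore expected in this assay and the estimate is a number 0.49 log units lower from compound 3 to compound 4 (beyond the scatter) for this change. Compound 4 is expected at 4.6 within an estimated range from 4.25 to 4.95 on this reading.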

Compound 4, partition coefficient: 5.03
Beside the measured number, compound 4's estimate is 0.43 log units below it, outside the stated range (above it).
By their numbers in this assay, from the lowest: compounds 2, 4, 3 and 1 (each within the scatter of the next, the first and the last beyond it).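

In this assay, dimethylamino in place of fluoro on an aromatic carbon, para to a large group, gives a number 0.06 log units lower from compound 3 to compound 4 (within the scatter), so on this 4-nitrophenyl compound the exchange cannot be told from the scatter, whereas the earlier exchange from chloro gave a number 0.58 log units lower from compound 1 to compound 2 (beyond the scatter). The step from the other dimethylamino compound, with 4-nitrophenyl in place of 2-nitrophenyl, is a number 0.23 log units higher from compound 2 to compound 4 (within the scatter), so with dimethylamino present the placing of the nitro group also stays within the scatter on this scale, and a step beyond the scatter for one exchange on the shared core therefore did not recur for a closely related one. No measurement at hand accounts for the difference between these two exchanges.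

The compounds shown leave open whether the contrast belongs to the group that leaves, chloro or fluoro, or to the placing of the nitro group, since these two differ together between the two exchanges. They also leave open whether a methoxy group or a morpholine ring at this place would stay within the scatter of fluoro, as dimethylamino does in compound 4.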